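A few compounds are considered here, and "the series" means these few. Any claim that something is new, unique, unknown or untested is made for them only; others in the source may bear on it.

Measured compounds in a functional assay on the whole organism (strain albino) for inhibition, with Rattus norvegicus as the target, read by paw edema, with stated times of 1 h and 2 h, at a dose of 20 mmol/kg by the intraperitoneal route; on this read-out higher numbers stand for more inhibition at the one dose given (going by the name of the read-out) and lower numbers for less inhibition:
Compound 1, `N#CC1=C(NCC(=O)N2CCOCC2)N(c2ccccc2)C(=O)N2CCCCC(N3CCCC3)C12`, gives 69.8%.
Compound 2, `N#CC1=C(NCC(=O)O)N(c2ccccc2)C(=O)N2CCCCC(N3CCCC3)C12`, gives 81.7%.
Compound 3, `COC(=O)C(=O)NC1=C(C#N)C2C(N3CCCC3)CCCCN2C(=O)N1c1ccccc1`, gives 85.6%.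

Compound 3 holds the highest of the three numbers. Its nearest neighbour is compound 2, and that gap is within the scatter (a number 3.9 percentage points higher from compound 2 to compound 3 (within the scatter)), so no order between compound 2 and compound 3 is claimed. Compound 1 lies furthest off, beyond the scatter (a number 15.8 percentage points higher from compound 1 to compound 3 (beyond the scatter)).

The next compound, compound 4, `N#CC1=C(NCC(=O)N2CCCCC2)N(c2ccccc2)C(=O)N2CCCCC(N3CCCC3)C12`, is not yet measured. Its change from compound 3: ((piperidin-1-yl)carbonyl)methyl in place of (methoxycarbonyl)carbonyl on an amine nitrogen.

The step that bears most directly is a number 15.8 percentage points higher from compound 1 to compound 3 (beyond the scatter), since compound 1 differs from compound 4 only in carrying morpholin-4-yl where compound 4 carries piperidin-1-yl; the step from compound 3 to compound 4 runs the other way across the same position. The step of a number 11.9 percentage points higher from compound 1 to compound 2 (beyond the scatter) points the same way, modest in size. The expected step is therefore downward, of modest size: a number 13.6 percentage points lower from compound 3 to compound 4 (beyond the scatter).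

For compound 4 the estimate in this assay is 72%, with a range from 60% to 84%.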

Compound 4, a percentage reported as inhibition, in the whole organism at one dose (the size of the read-out at that dose, not a potency): 46.1%
For compound 4 the middle estimate is 25.9 percentage points above the measured one; measured number outside the range, below it.
By their numbers in this assay, from the lowest: compound 4; then compound 1; then compounds 2 and 3 (each within the scatter of the next).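

In this assay, the group on the carbonyl carbon matters even when both compounds are amides: piperidin-1-yl in place of morpholin-4-yl gives a number 23.7 percentage points lower from compound 1 to compound 4 (beyond the scatter). Against the hydroxy and (methoxycarbonyl)carbonyl compounds, which stand within the scatter of each other, the ((piperidin-1-yl)carbonyl)methyl compound falls much further, with a number 35.6 percentage points lower from compound 2 to compound 4 (beyond the scatter) and a number 39.5 percentage points lower from compound 3 to compound 4 (beyond the scatter), so this position spans a far wider range than the first three compounds showed. No measurement at hand explains the drop.

As far as these compounds go, how other groups on that carbonyl carbon would read remains open, for example methoxy, dimethylamino or piperazin-1-yl. Also open, from the compounds shown here alone, is whether a longer chain on the amine nitrogen would keep the same order.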